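Cytotoxicity notes on a small series of four compounds

The compounds below may be only part of what the source reports. "The series", "measured", "known", "first", "only" and "open" are said of these compounds alone.

Compound 1 `C/C(=N\NC(N)=O)c1ccc2[nH]c(-c3ccoc3)nc2c1` is examined in an ADME assay on BHK-21 cells (Mesocricetus auratus) for cytotoxicity, read by MTT assay; on this read-out lower numbers stand for higher toxicity in this test and higher numbers for lower toxicity in this test. For compound 1 the result is a limit of the assay, > 100000 nM. Compound 2 `C/C(=N\NC(N)=O)c1ccc2[nH]c(C3CCCCC3)nc2c1` carries the change (cyclohexyl in place of furan-3-yl on an aromatic carbon); for compound 2 the result is likewise a limit, > 100000 nM. The step that the two limits leave unreadable from compound 1 to compound 2 therefore cannot be sized. Compound 3 `C/C(=N\NC(N)=S)c1ccc2[nH]c(-c3ccoc3)nc2c1` differs from compound 1 by a group of 3 heavy atoms (1 carbon, 1 nitrogen, 1 sulfur; no ring) in place of a group of 3 heavy atoms (1 carbon, 1 nitrogen, 1 oxygen; no ring), on an amine nitrogen; for compound 3 the outcome is again a limit, > 100000 nM. The step that the two limits leave unreadable from compound 1 to compound 3 is equally unreadable, since every result so far sits at the limit of > 100000 nM in this assay, at which 3 of the 3 values shown sit. Compound 4 `C/C(=N\NC(N)=S)c1ccc2[nH]c(C3CCCCC3)nc2c1` is not yet measured; it differs from compound 3 by cyclohexyl in place of furan-3-yl on an aromatic carbon, the same change as that from compound 1 to compound 2. Compound 4 is expected to show a step that the limit leaves unreadable from compound 3 to compound 4, beside the earlier step that the two limits leave unreadable from compound 1 to compound 2, an expectation resting on (the limit of > 100000 nM in this assay, at which 3 of the 3 values shown sit). Compound 4 is estimated at 150000 nM, most likely reported only as a limit again, within 60000 nM to 400000 nM.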

Compound 4, half-maximal cytotoxic concentration: 24000 nM
Compound 4: middle estimate off by 6.3-fold (0.80 log units), on the high side; measured number below the stated range.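

In this assay, cyclohexyl in place of furan-3-yl gives an at least 4.1-fold lower number from compound 3 to compound 4 (0.61 log units; beyond the scatter), and the sulfur-bearing group in place of the oxygen-bearing group on the amine nitrogen gives an at least 4.1-fold lower number from compound 2 to compound 4 (0.61 log units; beyond the scatter). Both steps are bounded on one side only, so they show a real drop on the core of compound 3 and give no exact size. They do not show whether the change carries from one core to the other, since the steps among compounds 1, 2 and 3 cannot be read: the limit of > 100000 nM in this assay, at which 3 of the 4 values shown sit.

Still open, going by these compounds, is whether the step is tied to cyclohexyl itself. An amine, a carboxylic acid or a longer carbon chain on the same aromatic carbon would test this on either core.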